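Working notes on the step from compound 1 to compound 3

This account rests on a few compounds, and the source may have more. Where it says the series, first, only, none or still open, it means among the compounds named here.

Measured so far in a functional assay on HeLa cells (Homo sapiens) for antiproliferative activity, with a stated time of 24 h; on this read-out higher numbers stand for weaker inhibition and lower numbers for stronger inhibition:
compound 1 `NC(=O)c1c(NC(=O)c2ccccc2Cl)sc2c1CCN(Cc1ccc([N+](=O)[O-])cc1)C2`: 46100 nM
compound 2 `NC(=O)c1c(NC(=O)c2ccc(C(F)(F)F)cc2)sc2c1CCN(Cc1c(Cl)cccc1Cl)C2`: > 50000 nM, which is a limit of this assay and not a number

Within the data shown here, compound 1 is the only member with a numerical value in this assay, and that value is weak. For compound 2 the assay gives only a limit, (the limit of > 50000 nM in this assay, at which 1 of the 2 values shown sits). Among the measured compounds shown here, no pair of measured compounds differs in one place, so no measured step is available.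

Compound 3 `Cc1ccccc1NC(=S)N1CCc2c(sc(NC(=O)c3ccccc3Cl)c2C(N)=O)C1` differs from compound 1 by a group of 10 heavy atoms (8 carbon, 1 nitrogen, 1 sulfur; one six-membered aromatic ring of carbon only) in place of a group of 10 heavy atoms (7 carbon, 1 nitrogen, 2 oxygen; one six-membered aromatic ring of carbon only), on an amine nitrogen in a ring.

For the measured compounds named here, with no step measured, the expectation rests on compound 1 alone: compound 3 is expected to stay near it, with a step from compound 1 to compound 3 of a 1.2-fold lower number from compound 1 to compound 3 (0.06 log units; within the scatter), not clearly beyond the scatter in either direction. Compound 3 is therefore estimated at 40000 nM in this assay, within 12000 nM to 130000 nM.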

Compound 3, half-maximal inhibitory concentration: > 50000 nM
Compound 3: no number, only a limit (the forecaster's own chance of this, stated with the estimate: 40%); middle value at least 1.2-fold (0.09 log units) from the limit.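

In this assay compound 3 gives > 50000 nM, which is a limit of the assay and not a number. As far as these compounds go, exchanging 4-nitrobenzyl for the entering group on the amine nitrogen in a ring gives an at least 1.0-fold higher number from compound 1 to compound 3 (0.03 log units; that floor lies within the scatter), so this change shows no gain in inhibition at this position, and the true size of the step stays unknown. The series now rests mostly on limits, with compound 1 still the only member holding a numerical value: the limit of > 50000 nM in this assay, at which 2 of the 3 values shown sit.

From the compounds shown here alone, whether a methyl group on this nitrogen, or a benzyl group carrying an amine or a carboxylic acid in place of the nitro group, would give a number clearly lower than that of compound 1 stays open. Going by these compounds, the amide side of the core also stays open, as compound 2 differs from compound 1 in more than one place and gives no readable step.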